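Histamine H2 agonist series: acylguanidine enantiomer pair

A few compounds are considered here, and "the series" means these few. Any claim that something is new, unique, unknown or untested is made for them only; others in the source may bear on it.

Measured so far:
compound 1 `Cc1nc(N)sc1CCCNC(=N)NC(=O)C[C@H](C)C1CCCCC1`: 91.2 nM
compound 2 `C[C@H](CC(=O)NC(=N)NCCCc1c[nH]cn1)c1ccccc1`: 93.3 nM

In a functional assay on cardiac atrium for agonist activity at histamine H2 receptor (Cavia porcellus) (a lower number here means that less compound is needed, a higher number that more compound is needed for the effect), compound 1 gives 91.2 nM, the lowest of the two numbers, with compound 2 at 93.3 nM, within the scatter of it. Compound 3 `Cc1nc(N)sc1CCCNC(=N)NC(=O)C[C@@H](C)C1CCCCC1` differs from compound 1 as follows: the two compounds have the same atoms and bonds; at least one stereo element is drawn with a configuration in one of them and without one in the other: 1 of 2 stereo elements differ; a stereocentre at a saturated chain carbon is drawn S in compound 1 and R in compound 3. For the measured compounds named here, no step of this kind has been measured in this assay, so the size and direction rest on expectation alone; a stereocentre inversion at a chain carbon may shift the number beyond the scatter, more likely upward. For compound 3 the expected value is 220 nM, range 50 nM to 1000 nM, which means an expected step of a 2.4-fold higher number from compound 1 to compound 3 (0.38 log units; beyond the scatter).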

Compound 3, half-maximal effective concentration: 57.5 nM
For compound 3 the middle estimate is 3.8-fold (0.58 log units) above the measured one; measured number inside the range.
By their numbers in this assay, from the lowest: compounds 3, 1 and 2 (each within the scatter of the next).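

In this assay, inverting the stereocentre at the saturated chain carbon from S to R gives a 1.6-fold lower number from compound 1 to compound 3 (0.20 log units; within the scatter), the first step measured at this position. On this core, then, this assay does not separate the S and R drawings at this carbon. One caveat applies to reading the pair as a clean inversion: the fact that one of compounds 1 and 3 is drawn with a defined configuration and the other without, at the place where they differ.

On these data alone, whether the same inversion stays within the scatter on the core of compound 2 remains open. Also open, as far as these compounds go, is how a longer chain or an amine at this carbon would read.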